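A few compounds are considered here, and "the series" means these few. Any claim that something is new, unique, unknown or untested is made for them only; others in the source may bear on it.

Three macrocycles built on one shared core differ only in the length of a saturated chain within the ring. Compound 1 `CC(C)C[C@@H]1NC(=O)[C@@H](NC(=O)OCc2ccccc2)Cc2cn(nn2)CCNC(=O)CC[C@@H](C=O)NC1=O` has the shortest chain. In an ADME assay on HG23 cells (Homo sapiens) for cytotoxicity, with a stated time of 72 h (a lower number here means that less compound is tolerated, a higher number that more compound is tolerated), compound 1 gives > 100000 nM, which is a limit of the assay and not a number. Compound 2 `CC(C)C[C@@H]1NC(=O)[C@@H](NC(=O)OCc2ccccc2)Cc2cn(nn2)CCCNC(=O)CC[C@@H](C=O)NC1=O` has a longer chain. In this assay compound 2 gives > 100000 nM, again a limit. Compound 3 `CC(C)C[C@@H]1NC(=O)[C@@H](NC(=O)OCc2ccccc2)Cc2cn(nn2)CCCCNC(=O)CC[C@@H](C=O)NC1=O` has the longest chain of the three. In this assay compound 3 gives > 100000 nM, also a limit. Within the data shown here, compound 3 therefore stands exactly where the other two stand, at the limit of > 100000 nM in this assay, at which 3 of the 3 values shown sit, and no measured step exists among them.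

Compound 4 `O=C[C@@H]1CCC(=O)NCCCCn2cc(nn2)C[C@H](NC(=O)OCc2ccccc2)C(=O)N[C@@H](CC2CCCCC2)C(=O)N1` keeps the chain of compound 3 and differs by cyclohexyl in place of isopropyl on a saturated chain carbon bound to a saturated ring carbon. Without any measured step to lean on, no change beyond the usual scatter is expected; all three measured compounds sit at the limit, and compound 4 is expected to do the same. The expected step from compound 3 to compound 4 is a number no higher from compound 3 to compound 4 (the limit leaves the size open). Compound 4 is estimated at 100000 nM, within 40000 nM to 300000 nM, most likely again reported only as a limit.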

Compound 4, half-maximal cytotoxic concentration: > 100000 nM
Compound 4: only a limit was reported; the forecaster's own chance of this, stated with the estimate: 85%; the middle value lies on the limit itself.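

Among these compounds, compound 3 and compound 4 are both reported in this assay only as limits, so no step between them can be read. Whether chain length or cyclohexyl in place of isopropyl alters cytotoxicity at any higher concentration remains open for all compounds shown.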